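Allyl to 3-Hydroxypropyl on the Triazole: Compound 4 Expected

The compounds below may be only part of what the source reports. "The series", "measured", "known", "first", "only" and "open" are said of these compounds alone.

Three compounds have been measured in a functional assay on RAW264.7 cells (Mus musculus) for inhibition, read by Griess assay, with stated times of 2 h and 24 h; a higher number here means a weaker inhibitor, a lower number a stronger inhibitor:
Compound 1, `COc1ccc([C@@H]2CC(=O)c3c(O)cc(OCc4cn(Cc5cccc(C(F)(F)F)c5)nn4)cc3O2)cc1O`, gives 19900 nM.
Compound 2, `COc1ccc([C@@H]2CC(=O)c3c(O)cc(OCc4cn(Cc5cccc(C#N)c5)nn4)cc3O2)cc1O`, gives 18000 nM.
Compound 3, `C=CCn1cc(COc2cc(O)c3c(c2)O[C@H](c2ccc(OC)c(O)c2)CC3=O)nn1`, gives 13800 nM.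

Compound 3 stands within the scatter of both neighbours: a 1.4-fold lower number from compound 1 to compound 3 (0.16 log units; within the scatter) and a 1.3-fold lower number from compound 2 to compound 3 (0.12 log units; within the scatter). Compound 4, `COc1ccc([C@@H]2CC(=O)c3c(O)cc(OCc4cn(CCCO)nn4)cc3O2)cc1O`, differs from compound 3 by 2-hydroxyethyl in place of vinyl on a saturated chain carbon bound to an aromatic nitrogen. For the measured compounds named here, no measured step swaps vinyl for 2-hydroxyethyl; the only steps touching this position, a 1.4-fold lower number from compound 1 to compound 3 (0.16 log units; within the scatter) and a 1.3-fold lower number from compound 2 to compound 3 (0.12 log units; within the scatter), stayed within the scatter, and a 1.1-fold lower number from compound 1 to compound 2 (0.04 log units; within the scatter) did likewise. The three numbers give no foothold for a shift in either direction, so for compound 4 the step of a 1.1-fold higher number from compound 3 to compound 4 (0.04 log units; within the scatter) is expected to stay within the scatter. Compound 4 is therefore estimated at 15000 nM, with a range of 6000 nM to 38000 nM.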

Compound 4, half-maximal inhibitory concentration: 16700 nM
For compound 4 the middle estimate is 1.1-fold (0.05 log units) below the measured one, within the range that was stated.
By their numbers in this assay, from the lowest: compounds 3, 4, 2 and 1 (each within the scatter of the next).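

In this assay, for the compounds shown here, 2-hydroxyethyl, the only group here at this position with a hydrogen-bond donor, still leaves the number within the scatter of the other three compounds (a 1.2-fold higher number from compound 3 to compound 4 (0.08 log units; within the scatter); a 1.1-fold lower number from compound 2 to compound 4 (0.03 log units; within the scatter); a 1.2-fold lower number from compound 1 to compound 4 (0.08 log units; within the scatter)). Vinyl, both substituted phenyl groups and 2-hydroxyethyl, on a saturated chain carbon bound to an aromatic nitrogen, therefore read alike across these four compounds. No measurement shown accounts for this flat reading.

The compounds shown leave open whether an amine, a carboxylic acid or a longer chain ending in hydroxyl at this position would move the number beyond the scatter.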